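A few compounds are considered here, and "the series" means these few. Any claim that something is new, unique, unknown or untested is made for them only; others in the source may bear on it.

Measured in a functional assay on HCT-116 cells (Homo sapiens) for inhibition, read by colorimetric assay, with a stated time of 3 days; a higher number here means a weaker inhibitor, a lower number a stronger inhibitor:
- compound 1 `O=C(CCCCCCNC(=O)C(O)(O)C(F)(F)F)Nc1ncc(-c2ccc(O)cc2)s1`: 1020 nM
- compound 2 `O=C(CCCCCCNC(=O)C(O)(O)C(F)(F)F)Nc1ncc(-c2ccccc2)s1`: 2660 nM
- compound 3 `O=C(CCCCNC(=O)C(O)(O)C(F)(F)F)Nc1ccccc1`: 20300 nM

Compound 3 has the highest number of the three in this assay, so it is the weakest inhibitor here. Its value stands above those of compound 2 and compound 1, but it differs from both in more than one place.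

The next comparison is with compound 4 `O=C(CCCCNC(=O)c1cc(=O)c(O)co1)Nc1ccccc1`, which keeps the rest of compound 3 and changes the group on a carbonyl carbon: a group of 8 heavy atoms (5 carbon, 3 oxygen; one six-membered aromatic ring with 1 hetero atom) in place of a group of 7 heavy atoms (2 carbon, 2 oxygen, 3 fluorine; no ring), on a carbonyl carbon.

Going by the values given here, only one measured step exists, a 2.6-fold higher number from compound 1 to compound 2 (0.42 log units; beyond the scatter). It is hydrogen in place of hydroxy on an aromatic carbon, so it was made at a different place and gives only a general idea of how large a single change can be. Among the compounds with values here, no measured compound carries the entering group, so the data give no direct size or direction for this replacement.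

The expected change is none beyond the scatter, with a slight lean to a higher number: a 1.5-fold higher number from compound 3 to compound 4 (0.17 log units; within the scatter). For compound 4 the estimated value is 30000 nM, with an expected range of 8000 nM to 100000 nM.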

Compound 4, half-maximal inhibitory concentration: > 100000 nM
Compound 4: only a limit was reported (the forecaster's own chance of this, stated with the estimate: 30%); middle value at least 3.3-fold (0.52 log units) away from the limit.
By their numbers in this assay, from the lowest: compound 1; then compound 2; then compound 3. At a limit, above all of these: compound 4.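

In this assay, going by these compounds alone, the first measured change on this carbonyl carbon gives an at least 4.9-fold higher number from compound 3 to compound 4 (0.69 log units; beyond the scatter), so the direction at this position is now known: the 2,2,2-trifluoro-1,1-dihydroxyethyl group cannot be exchanged for the six-membered aromatic ring group of compound 4 without a loss of inhibition. Compound 4 is reported only as a limit, so the step sets a minimum size and the true size stays unknown: the limit of > 100000 nM in this assay, at which 1 of the 4 values shown sits.

On these data alone, whether the same exchange costs as much on the core of compound 1 or compound 2 remains open. Also open, as far as these compounds go, is how a smaller group on this carbonyl carbon, such as a methyl or a carboxylic acid, would read in this assay.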